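Swapping bromo for cyano on a fused ring

This account rests on a few compounds, and the source may have more. Where it says the series, first, only, none or still open, it means among the compounds named here.

Compound 1 `Cn1cncc1C(CC(=O)O)c1ccc(OCC2COc3ccc(Cl)cc3O2)cc1`: 3060 nM
Compound 2 `CC#C[C@@H](CC(=O)O)c1ccc(OC[C@H]2COc3c(Cl)cccc3O2)cc1`: 170 nM
Compound 3 `CC#C[C@@H](CC(=O)O)c1ccc(OC[C@H]2COc3ccc(Br)cc3O2)cc1`: 210 nM

All three were tested in a functional assay on HEK293 cells for agonist activity at Free fatty acid receptor 1 (Homo sapiens), read by fluorescence and calcium flux, with a stated time of 10 min; on this read-out lower numbers stand for an effect already at smaller amounts and higher numbers for an effect only at larger amounts of compound. Compound 3 sits second highest of the three numbers. Its closest neighbour is compound 2, whose number is lower by an amount that lies within the scatter, so the two cannot be told apart. Compound 1 stands far from both, with a number higher by more than the scatter allows; compound 1 differs from compound 3 in more than one place, so its values show only that a gap exists, not where it comes from.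

The next compound, compound 4 `CC#C[C@@H](CC(=O)O)c1ccc(OC[C@H]2COc3ccc(C#N)cc3O2)cc1`, changes one thing relative to compound 3: cyano in place of bromo on an aromatic carbon. Both groups sit on the same aromatic carbon of the fused two-ring system. Going by the values given here, no comparable swap appears among the measured compounds, so there is no reference step to lean on. A change of this kind, one small group for another at the same position, is expected to move the number little, most likely within the scatter of this assay, without a clear direction.

Compound 4 is therefore estimated at 260 nM, with a range from 90 nM to 750 nM. The expected step of a 1.2-fold higher number from compound 3 to compound 4 (0.09 log units; within the scatter) is small.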

Compound 4, half-maximal effective concentration: 2100 nM
Estimate against measurement, compound 4: 8.1-fold (0.91 log units) below, and the stated range ends below it.
By their numbers in this assay, from the lowest: compounds 2 and 3 (each within the scatter of the next); then compounds 4 and 1 (each within the scatter of the next).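

In this assay the swap of bromo for cyano on this aromatic carbon gives a 10-fold higher number from compound 3 to compound 4 (1.00 log units; beyond the scatter), so the number here clearly depends on which small group the carbon carries. The earlier compounds shown here could not show this: none of them formed a pair differing in one place, so no change in the number could be tied to a single position. What lies behind a step of this size remains unexplained, with no measurement at hand that speaks to it.

As far as these compounds go, with only bromo and cyano compared on this carbon, it remains open whether cyano is the exception or bromo is. A fluoro, a methyl, a methoxy or an amine on the same carbon, with the rest of compound 3 unchanged, would help to settle that.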